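The source may report more compounds than this note shows. Statements on the series, on what has been measured and on what is new or still open speak of the compounds shown alone.

Working notes on the series. Compound 1 `CCCCNc1nc(SC(C)C)nc2ncccc12` gives 15700 nM in a functional assay on MDA-MB-231 cells (Homo sapiens) for cytotoxicity, read by neutral red uptake, with a stated time of 72 h; on this read-out higher numbers stand for weaker inhibition and lower numbers for stronger inhibition. Compound 2 `CCCCCNc1nc(SC(C)C)nc2ncccc12` gives 5600 nM in this assay, and compound 3 `CCCCNc1nc(SCCCC)nc2ncccc12` gives 8400 nM in this assay. The change from compound 1 to compound 2 is methyl in place of hydrogen on a saturated chain carbon, four bonds along the chain from a nitrogen on an aromatic ring; it brings a 2.8-fold lower number from compound 1 to compound 2 (0.45 log units; beyond the scatter). Compound 3 differs from compound 1 in its core by butyl in place of isopropyl on a sulfur, and that step is a 1.9-fold lower number from compound 1 to compound 3 (0.27 log units; within the scatter). For the measured compounds named here, no step is counted here between compound 2 and compound 3; their two numbers sit close together.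

Compound 4 `CCCCCNc1nc(SCCCC)nc2ncccc12` is not yet measured. It differs from compound 3 by methyl in place of hydrogen on a saturated chain carbon, four bonds along the chain from a nitrogen on an aromatic ring, the same change that separates compound 1 from compound 2, now made on the core of compound 3. The step from compound 3 to compound 4 is expected to be a 2.5-fold lower number from compound 3 to compound 4 (0.39 log units; beyond the scatter), of about the size seen once before. That expectation rests on compound 1 and compound 2, whose step a 2.8-fold lower number from compound 1 to compound 2 (0.45 log units; beyond the scatter) lies beyond the scatter, though a single precedent leaves the estimate loose. Compound 4 is therefore expected to give 3400 nM in this assay, with a range from 1500 nM to 7500 nM.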

Compound 4, half-maximal inhibitory concentration: 6300 nM
Compound 4: middle estimate off by 1.9-fold (0.27 log units), on the low side, within the range that was stated.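

In this assay, for the compounds shown here, the methyl in place of hydrogen on a saturated chain carbon, four bonds along the chain from a nitrogen on an aromatic ring, gives a 1.3-fold lower number from compound 3 to compound 4 (0.12 log units; within the scatter), and this step cannot be told apart from the earlier one: the same change on two cores in this assay, a 2.8-fold lower number (0.45 log units; beyond the scatter) from compound 1 to compound 2 and a 1.3-fold lower number (0.12 log units; within the scatter) from compound 3 to compound 4, 2.1-fold (0.32 log units) apart, within the scatter of two such steps Butyl in place of isopropyl on a sulfur, made on the second core, gives a 1.1-fold higher number from compound 2 to compound 4 (0.05 log units; within the scatter), and it too cannot be told apart from its earlier counterpart: the same change on two cores in this assay, a 1.9-fold lower number (0.27 log units; within the scatter) from compound 1 to compound 3 and a 1.1-fold higher number (0.05 log units; within the scatter) from compound 2 to compound 4, 2.1-fold (0.32 log units) apart, within the scatter of two such steps Both changes therefore carry from one core to the other without a measurable difference, but with only one pair of steps for each change, this does not show that their sizes are truly equal or that the two changes add up.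

The compounds shown leave open whether the same steps would hold for a longer chain such as hexyl, or for a cyclohexyl ring or a terminal amine in place of these chains. From the compounds shown here alone, whether the steps hold beyond this assay also remains open.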